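The compounds below may be only part of what the source reports. "The series", "measured", "known", "first", "only" and "open" are said of these compounds alone.

In an ADME assay on cells (Homo sapiens) for cytotoxicity, read by resazurin assay, with a stated time of 5 days (a lower number here means that less compound is tolerated, a higher number that more compound is tolerated), three compounds sharing one core have so far given no exact number. Compound 1 `COc1ccc(-c2nc(C(F)(F)S(=O)(=O)c3cccc(Cl)c3)nc3ccsc23)cn1` gives > 50000 nM, which is a limit. Compound 2 `COc1ccc(-c2nc(C(C)S(=O)(=O)c3cccc(Cl)c3)nc3ccsc23)cn1` gives > 50000 nM, also a limit. Compound 3 `COc1ccc(-c2nc(CS(=O)(=O)c3cccc(Cl)c3)nc3ccsc23)cn1` gives > 10000 nM, again a limit and not a number. Compound 4 `O=S(=O)(Cc1nc(-c2ccc(F)nc2)c2sccc2n1)c1cccc(Cl)c1` carries 6-fluoropyridin-3-yl where compound 3 carries 6-methoxypyridin-3-yl, fluoro in place of methoxy on an aromatic carbon. Among the measured compounds shown here, the only measured step, a step that the two limits leave unreadable from compound 2 to compound 3, lies at another place and has no readable size, so no step beyond the scatter is expected in this assay. For compound 4 the estimate is 30000 nM, with an expected range from 8000 nM to 70000 nM. This estimate means an expected step that the limit leaves unreadable from compound 3 to compound 4.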

Compound 4, half-maximal cytotoxic concentration: 40000 nM
The estimate for compound 4 lay 1.3-fold (0.12 log units) below the measured number; low and high end bracket the measured number.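

In this assay, among the compounds shown here, compound 3 gives > 10000 nM, a limit and not a number, so no step to compound 4 can be read. The compounds shown leave open whether fluoro in place of methoxy changes how much compound is tolerated.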